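A Second Chlorine Joins the Amide Aryl Group

The compounds below may be only part of what the source reports. "The series", "measured", "known", "first", "only" and "open" are said of these compounds alone.

Three compounds share one core and differ only in the aryl group attached to the amide nitrogen. Compound 1 `O=C(CSc1nc(Nc2ccccc2)c2ccccc2n1)Nc1ccccc1Cl` carries a 2-chlorophenyl there; in a functional assay on MDA-MB-231 cells (Homo sapiens) for inhibition, read by MTT assay, with a stated time of 72 h (a higher number here means a weaker inhibitor, a lower number a stronger inhibitor), compound 1 gives 24400 nM. Compound 2 `O=C(CSc1nc(Nc2ccccc2)c2ccccc2n1)Nc1ccc(F)cc1` gives 34100 nM, and compound 3 `O=C(CSc1nc(Nc2ccccc2)c2ccccc2n1)Nc1ccc([N+](=O)[O-])cc1` gives 16800 nM. Compound 1 thus stands second highest of the three numbers: the step of a 1.4-fold higher number from compound 1 to compound 2 (0.15 log units; within the scatter) and the step of a 1.5-fold lower number from compound 1 to compound 3 (0.16 log units; within the scatter) both stay within the scatter, while the step of a 2.0-fold lower number from compound 2 to compound 3 (0.31 log units; beyond the scatter) is modest.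

Compound 4 `O=C(CSc1nc(Nc2ccccc2)c2ccccc2n1)Nc1ccc(Cl)c(Cl)c1` is not yet measured. Its change from compound 1 reads (3,4-dichlorophenyl in place of 2-chlorophenyl on an amide-type nitrogen). For the measured compounds named here, no measured step swaps a 2-chlorophenyl for a 3,4-dichlorophenyl, so the nearest guidance is that three different aryl groups on this amide nitrogen all landed in a narrow band, the widest gap being the modest step of a 2.0-fold lower number from compound 2 to compound 3 (0.31 log units; beyond the scatter). The estimated step is a 1.4-fold lower number from compound 1 to compound 4 (0.13 log units; within the scatter), not beyond the scatter. Compound 4 is therefore expected to give about 18000 nM, within 8000 nM to 40000 nM.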

Compound 4, half-maximal inhibitory concentration: 14500 nM
For compound 4 the middle estimate is 1.2-fold (0.09 log units) above the measured one, and the stated range covers the measured number.
By their numbers in this assay, from the lowest: compounds 4, 3, 1 and 2 (each within the scatter of the next, the first and the last beyond it).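

In this assay, the 3,4-dichlorophenyl group of compound 4 cannot be told apart from the 2-chlorophenyl group, with a 1.7-fold lower number from compound 1 to compound 4 (0.23 log units; within the scatter), or from the 4-nitrophenyl group, with a 1.2-fold lower number from compound 3 to compound 4 (0.06 log units; within the scatter). Only the comparison with the 4-fluorophenyl group stands clear of the scatter, with a 2.4-fold lower number from compound 2 to compound 4 (0.37 log units; beyond the scatter), a modest step that is now the widest gap among these aryl groups on the amide-type nitrogen, so an aryl group carrying two chlorines also fits this narrow band. No measurement is available that would explain these steps.

On these data alone, all four compounds carry a substituted phenyl on this nitrogen, so it remains open how an unsubstituted phenyl or a non-aromatic group, such as a short chain ending in an amine or a carboxylic acid, would compare. The phenylamino group on the shared core is also the same throughout, which leaves its contribution untested.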